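This account rests on a few compounds, and the source may have more. Where it says the series, first, only, none or still open, it means among the compounds named here.

Measured so far in a functional assay on a cell-free system (plasma) for inhibition of thromboxane A2 receptor (Homo sapiens); on this read-out higher numbers stand for weaker inhibition and lower numbers for stronger inhibition:
compound 1 `O=C(O)CCC/C=C\CC1C2CCC(O2)C1CSCCCc1ccccc1` gives 5000 nM;
compound 2 `CCSCC1C2CCC(O2)C1C/C=C\CCCC(=O)O` gives 5400 nM.

Compound 2 and compound 1 stand side by side on these two numbers: the step of a 1.1-fold higher number from compound 1 to compound 2 (0.03 log units; within the scatter) is too small to tell the two apart, so neither can be called the stronger inhibitor of the pair. Both share the same core and the same acid-bearing chain; they differ only in what hangs on the sulfur.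

Compound 3 `CCC/C=C(\C)CSCC1C2CCC(O2)C1C/C=C\CCCC(=O)O` changes that same spot once more: a group of 6 heavy atoms (6 carbon; no ring) in place of one carbon atom, on a saturated chain carbon bound to a sulfur. Among the measured compounds shown here, the only measured step that bears on this kind of change is the one from compound 1 to compound 2, where a far larger swap at the sulfur, a 1.1-fold higher number from compound 1 to compound 2 (0.03 log units; within the scatter), left the number within the scatter. With just that one step to lean on, the expectation is that the sulfur substituent again matters little, and that compound 3 will land close to compound 2, with any shift a 1.4-fold lower number from compound 2 to compound 3 (0.13 log units; within the scatter) not beyond the scatter. Compound 3 is therefore estimated at 4000 nM, in a range from 1300 nM to 12000 nM, because compound 2 gave 5400 nM and the earlier change at this position produced only a 1.1-fold higher number from compound 1 to compound 2 (0.03 log units; within the scatter).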

Compound 3, half-maximal inhibitory concentration: 1100 nM
Compound 3: the middle estimate sits 3.6-fold (0.56 log units) above what was measured, outside the stated range (below it).
By their numbers in this assay, from the lowest: compound 3; then compounds 1 and 2 (each within the scatter of the next).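

Among the compounds shown here, the sulfur substituent does matter in this assay, which the first pair of compounds gave no sign of: a 4.9-fold lower number from compound 2 to compound 3 (0.69 log units; beyond the scatter) when a group of 6 carbon atoms with one double bond outside any ring replaces methyl, on a saturated chain carbon bound to a sulfur. The same group also improves on the larger substituent that holds a six-membered aromatic ring, with a 4.5-fold lower number from compound 1 to compound 3 (0.66 log units; beyond the scatter), so the new group stands apart from both earlier ones. Heavy-atom count alone does not order these results, since compound 3 carries fewer heavy atoms in this group than compound 1 and more than compound 2, yet compounds 1 and 2 remain within the scatter of each other; nothing given here explains the gain.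

The compounds shown leave open which part of the new group goes with the stronger inhibition: the double bond, the methyl branch on it, or simply the length of the chain, a question that a saturated hexyl chain could help to separate. They also leave open how a longer chain, or an amine at the end of the chain, would read in this assay.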